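The compounds below may be only part of what the source reports. "The series", "measured", "known", "first", "only" and "open" are said of these compounds alone.

Measured in a physicochemical assay for solubility, in phosphate buffer, with a stated time of 18 h; on this read-out higher numbers stand for higher solubility and lower numbers for lower solubility:
- compound 1 `CC(C)(C)c1nc(-c2ccncc2)c2c(N)c(C#N)c(N)nc2n1`: 44000 nM
- compound 2 `CC(C)(C)c1nc(-c2cnccn2)c2c(N)c(C#N)c(N)nc2n1`: 86000 nM

On these numbers, compound 2 is not clearly set apart. Among the compounds with values here, its value of 86000 nM lies within the scatter of compound 1 at 44000 nM, and with only two measurements there is little to rank it against.

Compound 3 `Cc1c[nH]c(-c2nc(C(C)(C)C)nc3nc(N)c(C#N)c(N)c23)n1` has yet to be measured. It carries 4-methyl-1H-imidazol-2-yl in place of pyrazin-2-yl on an aromatic carbon, at the same place on the shared core.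

Within the data shown here, only one measured step bears on this change: a 2.0-fold higher number from compound 1 to compound 2 (0.29 log units; within the scatter). That step exchanged pyridin-4-yl for pyrazin-2-yl at this place and stayed within the scatter. Among the measured compounds shown here, no measured compound carries 4-methyl-1H-imidazol-2-yl, so the data give no direction for the new group, and the range must stay wide. No shift beyond the scatter is expected in this assay. The expected step is a 1.6-fold lower number from compound 2 to compound 3 (0.19 log units; within the scatter), which leans towards the middle of the two measured values. For compound 3 the estimated value is 55000 nM, with an expected range from 18000 nM to 130000 nM.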

Compound 3, solubility: 5000 nM
For compound 3 the middle estimate is 11-fold (1.04 log units) above the measured one, outside the stated range (below it).
By their numbers in this assay, from the lowest: compound 3; then compounds 1 and 2 (each within the scatter of the next).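

In this assay, this position proved able to move the read-out well beyond the scatter: the change gives a 17-fold lower number from compound 2 to compound 3 (1.24 log units; beyond the scatter) at this place, whereas the earlier exchange of pyridin-4-yl for pyrazin-2-yl stayed within it. The fall does not depend on which of the two six-membered groups serves as the reference, since the same entering group also gives an 8.8-fold lower number from compound 1 to compound 3 (0.94 log units; beyond the scatter) in this comparison. Against pyrazin-2-yl, the heavy-atom count stays at 6, so the step goes with a five-membered aromatic ring carrying 1 hydrogen-bond donor replacing a six-membered aromatic ring with 0 hydrogen-bond donors, and nothing at hand explains why the number drops.

On these data alone, what remains open is which feature of the new group goes with the lower number: an unsubstituted 1H-imidazol-2-yl would separate the methyl group from the five-membered ring, and a thiazol-2-yl would show the outcome for a five-membered ring without the ring hydrogen. As far as these compounds go, it is also open how this position would respond to a group of a different kind, such as an amine or a carboxylic acid.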